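A few compounds are considered here, and "the series" means these few. Any claim that something is new, unique, unknown or untested is made for them only; others in the source may bear on it.

Going by the values given here, compound 3 `FC(F)(F)c1ccc(Nc2ncnc3sc(Nc4c(Cl)cccc4Cl)nc23)cc1Cl` gives 21 nM in a functional assay on HEK293 cells for antagonist activity at transient receptor potential cation channel subfamily V member 1 (Homo sapiens), read by calcium flux (a higher number here means a weaker inhibitor, a lower number a stronger inhibitor), the highest of the three numbers measured so far. Its nearest neighbour is compound 1 `FC(F)(F)c1ccc(Nc2ncnc3sc(Nc4c(Cl)cccc4Cl)nc23)cc1`, which gives 12 nM; the two lie within the usual scatter of each other, so nothing separates them. Compound 2 `O=S(=O)(c1ccc(Nc2ncnc3sc(Nc4c(Cl)cccc4Cl)nc23)cc1)N1CCCC1` gives 1 nM and stands clearly apart: the step of a 12-fold lower number from compound 1 to compound 2 (1.08 log units; beyond the scatter) is large and beyond the scatter, while a 1.8-fold higher number from compound 1 to compound 3 (0.24 log units; within the scatter) stays within it.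

Compound 4 `Cc1nc(Nc2ccc(C(F)(F)F)c(Cl)c2)c2nc(Nc3c(Cl)cccc3Cl)sc2n1` differs from compound 3 by methyl in place of hydrogen on an aromatic carbon, on the shared core, between two ring nitrogen atoms. Among the compounds with values here, both measured steps concern the aromatic ring that carries the trifluoromethyl group, not the core, so neither bears directly on this change, and the series holds no other example of a change on the core. Within the data shown here, with no relevant step to lean on, compound 4 is expected to stay close to compound 3, the step of a 1.2-fold higher number from compound 3 to compound 4 (0.08 log units; within the scatter) being expected not to exceed the scatter in either direction, and the width of the estimate reflects the absence of a precedent. In this assay compound 4 is therefore estimated at 25 nM, with a range from 8 nM to 80 nM.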

Compound 4, half-maximal inhibitory concentration: 3 nM
Beside the measured number, compound 4's estimate is 8.3-fold (0.92 log units) above it; measured number outside the range, below it.
By their numbers in this assay, from the lowest: compound 2; then compound 4; then compounds 1 and 3 (each within the scatter of the next).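

In this assay, the position on the shared core between two ring nitrogen atoms proves responsive: a 7.0-fold lower number from compound 3 to compound 4 (0.85 log units; beyond the scatter) is beyond the scatter, and the change is only a methyl, 1 heavy atom, in place of hydrogen. Going by these compounds alone, the earlier steps all lay on the aromatic ring carrying the trifluoromethyl group, so this is the first sign that a change on the core, and not only on that ring, can shift the number, here towards a stronger inhibitor. No measurement at hand explains why this methyl has this effect.

On these data alone, whether the same methyl gives a comparable step on compound 1, which lacks the added chloro, or on compound 2, with its (pyrrolidin-1-yl)sulfonyl group, remains open, so the effect rests on a single pair. Also open, as far as these compounds go, is how this position responds to a longer chain such as ethyl, to an amine or to a methoxy group, and so whether the shift is particular to methyl or extends to other groups at this place.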